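Pyrazole-free account: a cyclic amine replaces the benzyl amide

The source may hold more compounds than are shown below. What is called first, only, known or untested is meant among the compounds shown, and "the series" means these compounds.

Of the compounds shown here, two have been measured in an assay on microsomes from liver for inhibition of 3-hydroxy-3-methylglutaryl-coenzyme A reductase (Rattus norvegicus); on this read-out higher numbers stand for weaker inhibition and lower numbers for stronger inhibition. Compound 1 `Cc1ccc(CNC(=O)c2nn(-c3ccc(F)cc3)c(CC[C@@H](O)C[C@@H](O)CC(=O)O)c2C(C)C)cc1` gives 2.5 nM in this assay. Compound 2 `CC(C)c1c(C(=O)N(C)Cc2ccccc2)nn(-c2ccc(F)cc2)c1OC[C@@H](O)C[C@@H](O)CC(=O)O` gives 5.2 nM in this assay, the higher of the two numbers; the gap to compound 1 lies beyond the usual scatter, so compound 2 stands as the weaker of the pair. Among the measured compounds shown here, no step between compounds differing in one place is available, so nothing is known yet about how changes on the carbonyl carbon move the numbers.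

Compound 3 `CC(C)c1c(C(=O)N2CCC[C@H](c3ccccc3)C2)nn(-c2ccc(F)cc2)c1OC[C@@H](O)C[C@@H](O)CC(=O)O` is the next compound, not yet measured in this assay. It differs from compound 2 in one place: 3-phenylpiperidin-1-yl in place of benzyl(methyl)amino on a carbonyl carbon. The amide nitrogen stays, the phenyl ring stays, but the methyl and the benzyl carbon are folded into a ring.

Without a measured step of this kind, compound 3 is expected to stay close to compound 2, with a step of a 1.5-fold higher number from compound 2 to compound 3 (0.19 log units; within the scatter) that is estimated to be small and, if anything, toward a somewhat higher number. Compound 3 is therefore estimated at 8 nM in this assay, within a range from 2.5 nM to 25 nM.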

Compound 3, half-maximal inhibitory concentration: 4.8 nM
For compound 3 the middle estimate is 1.7-fold (0.22 log units) above the measured one; the range from low to high includes it.
By their numbers in this assay, from the lowest: compounds 1, 3 and 2 (each within the scatter of the next, the first and the last beyond it).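

In this assay, among the compounds shown here, 3-phenylpiperidin-1-yl in place of benzyl(methyl)amino on a carbonyl carbon gives a 1.1-fold lower number from compound 2 to compound 3 (0.03 log units; within the scatter), the first measured step at this position. The position therefore accepts this exchange without a change that can be told from the scatter, even though the group gains heavy atoms, a six-membered non-aromatic ring and a defined stereocentre, while the count of hydrogen-bond donors and acceptors stays at 0 and one six-membered aromatic ring of carbon only remains. Nothing at hand accounts for this result.

As far as these compounds go, with a single step, it stays open whether the other configuration at the stereocentre of 3-phenylpiperidin-1-yl, the isomeric 4-phenylpiperidin-1-yl, or plain piperidin-1-yl without its phenyl ring would also stay at this level. Also open, from the compounds shown here alone, is how the number would respond to groups on this carbonyl carbon that carry a hydroxyl, an amine or a carboxylic acid, since both groups compared here contain only carbon and the amide nitrogen.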